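A few compounds are considered here, and "the series" means these few. Any claim that something is new, unique, unknown or untested is made for them only; others in the source may bear on it.

Of the compounds shown here, three have so far been measured in a physicochemical assay for solubility, with a stated time of 24 h, at pH 4.5; on this read-out higher numbers stand for higher solubility and lower numbers for lower solubility. Compound 1 `c1cc2ccc(CN3CCCCC3)ccc-2c1` gives a value that is a limit of the assay rather than a number, > 56 ug/mL. Compound 2 `O=C(Nc1cc2cccccc-2c1)c1cccnc1` gives 3 ug/mL in this assay. Compound 3 `CN(C)C(=O)c1cn(C)c2ccccc12` likewise reaches a limit of the assay, > 51 ug/mL, so its standing among the three can only be placed at the upper end of what the assay reports. Two of the three values are limits, one at the limit of > 51 ug/mL in this assay, at which 1 of the 3 values shown sits, and one at the limit of > 56 ug/mL in this assay, at which 1 of the 3 values shown sits, and only compound 2 gives a number.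

Compound 4 `COC(=O)c1ccc2c(C(=O)N(C)C)cn(C)c2c1` has not yet been measured. It differs from compound 3 by methoxycarbonyl in place of hydrogen on an aromatic carbon. Within the data shown here, no step between two measured compounds is available to set the size of such a change. The step from compound 3 to compound 4 in this assay is nevertheless expected to run downward, an at least 1.7-fold lower number from compound 3 to compound 4 (0.23 log units; that floor lies within the scatter), a moderate loss rather than none. Compound 4 is therefore expected to give about 30 ug/mL in this assay, within a range from 10 ug/mL to 60 ug/mL.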

Compound 4, solubility: > 52 ug/mL
Compound 4 was reported as a limit; the forecaster's own chance of this, stated with the estimate: 30%; at least 1.7-fold (0.23 log units) between middle value and limit.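

Among these compounds, compound 3 and compound 4 both stand at limits of this assay, and no step between them can be read. The compounds shown leave open the size and the direction of the change that comes with methoxycarbonyl in place of hydrogen on an aromatic carbon.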